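This account rests on a few compounds, and the source may have more. Where it says the series, first, only, none or still open, it means among the compounds named here.

Compound 1 `CC(C)OC(=O)N1CCC(Oc2ncnc3c2CCN3c2ccc(-c3cccn3C)cc2F)CC1` and compound 2 `CCCCOC(=O)N1CCC(Oc2ncnc3c2CCN3c2ccc(S(C)(=O)=O)cc2F)CC1` share a core and differ in two places, so only their two values can be set side by side. In a functional assay on CHO-K1 cells with Glucose-dependent insulinotropic receptor (Homo sapiens) as the target, read by a luciferase reporter, with a stated time of 5 h (a lower number here means a smaller maximal response, a higher number a larger maximal response), compound 1 gives 44%, while compound 2 gives 131%. Going by the values given here, compound 2 thus stands highest of the two numbers known so far, with compound 1 a good deal lower, a gap beyond the usual scatter. Compound 3 `CCSC(=O)N1CCC(Oc2ncnc3c2CCN3c2ccc(S(C)(=O)=O)cc2F)CC1` keeps everything of compound 2 except one group on the carbonyl carbon: ethylsulfanyl in place of butoxy on a carbonyl carbon. Among the compounds with values here, no measured pair shows this change, so its effect rests on expectation alone. A modest fall is expected, as a step from a number 21 percentage points lower from compound 2 to compound 3 (beyond the scatter) in this assay. Compound 3 is therefore estimated at 110%, with a range from 70% to 145%, since the value of compound 2 at 131% is the only direct anchor.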

Compound 3, largest response reached (reported as percent of maximum), in percent of the reference or control that the assay uses: 128%
Estimate against measurement, compound 3: 18 percentage points below; low and high end bracket the measured number.
By their numbers in this assay, from the lowest: compound 1; then compounds 3 and 2 (each within the scatter of the next).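

In this assay, putting ethylsulfanyl in place of butoxy on a carbonyl carbon gives a number 3 percentage points lower from compound 2 to compound 3 (within the scatter), the first pair shown that differs at this position alone. The carbonyl carbon can therefore carry either butoxy, with 5 heavy atoms and an oxygen, or ethylsulfanyl, with 3 heavy atoms and a sulfur, with no readable difference in the maximal response. Nothing available explains why these two groups give such similar results.

The compounds shown leave open what a dimethylamino group or a longer chain such as hexyloxy would do on the same carbonyl carbon. They also leave open whether butoxy and ethylsulfanyl would still match if another group, such as a nitrile, replaced the methylsulfonyl group shared by compound 2 and compound 3.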